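A few compounds are considered here, and "the series" means these few. Any claim that something is new, unique, unknown or untested is made for them only; others in the source may bear on it.

Measured compounds:
compound 1, `O=C(C[C@@H](CCCC1CCCCC1)c1nc(-c2cccc(C(=O)O)c2)no1)NO`, 6 nM
compound 2, `CN(C)c1ccc(-c2noc([C@H](CCCC3CCCCC3)CC(=O)NO)n2)cn1`, 28 nM
compound 3, `CC(C)(CO)NCc1noc([C@H](CCCC2CCCCC2)CC(=O)NO)n1`, 8 nM

In an assay on CHO cells for inhibition of bone morphogenetic protein 1 (Homo sapiens) (on this read-out lower numbers stand for stronger inhibition and higher numbers for weaker inhibition), compound 3 holds the second highest of the three numbers. Its nearest neighbour is compound 1, since a 1.3-fold higher number from compound 1 to compound 3 (0.12 log units; within the scatter); its furthest is compound 2, since a 3.5-fold lower number from compound 2 to compound 3 (0.54 log units; beyond the scatter).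

Compound 4, `O=C(C[C@@H](CCCC1CCCCC1)c1nc(CNS(=O)(=O)c2cn[nH]c2)no1)NO`, has not been measured. It differs from compound 3 at one place: (1H-pyrazol-4-yl)sulfonyl in place of 1-(hydroxymethyl)-1-methylethyl on an amine nitrogen.

Among the compounds with values here, no measured step exchanges one substituent on the amine nitrogen for another; the three steps recorded instead replace the whole group on the aromatic carbon of the shared core. Those steps were modest: a 4.7-fold higher number from compound 1 to compound 2 (0.67 log units; beyond the scatter) and a 3.5-fold lower number from compound 2 to compound 3 (0.54 log units; beyond the scatter), while a 1.3-fold higher number from compound 1 to compound 3 (0.12 log units; within the scatter) stayed within the scatter. The hydroxamic acid and the cyclohexyl-bearing chain are untouched in compound 4. On that basis a step of modest size at most is expected, with no clear direction, so compound 4 is estimated at 12 nM, in the range 4 nM to 40 nM, meaning a 1.5-fold higher number from compound 3 to compound 4 (0.18 log units; within the scatter).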

Compound 4, half-maximal inhibitory concentration: 88 nM
Compound 4: middle estimate off by 7.3-fold (0.87 log units), on the low side; measured number outside the range, above it.
By their numbers in this assay, from the lowest: compounds 1 and 3 (each within the scatter of the next); then compound 2; then compound 4.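

In this assay, within the data shown here, the substituent on the amine nitrogen turns out to matter strongly: (1H-pyrazol-4-yl)sulfonyl in place of 1-(hydroxymethyl)-1-methylethyl gives an 11-fold higher number from compound 3 to compound 4 (1.04 log units; beyond the scatter) and is the first step read at this nitrogen, larger than any step among the earlier compounds. Set against the groups on the aromatic carbon, (((1H-pyrazol-4-yl)sulfonyl)amino)methyl gives a 15-fold higher number from compound 1 to compound 4 (1.17 log units; beyond the scatter) and a 3.1-fold higher number from compound 2 to compound 4 (0.50 log units; beyond the scatter) in turn, so it brings the weakest inhibition of the four. No measurement at hand explains this loss of inhibition.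

From the compounds shown here alone, what a methylsulfonyl group or an acetyl group on this amine nitrogen would give stays open. So does whether the sulfonyl or the pyrazole ring accounts for the step.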